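Changing the Group on the Carbonyl Carbon

A few compounds are considered here, and "the series" means these few. Any claim that something is new, unique, unknown or untested is made for them only; others in the source may bear on it.

Compound 1 `COc1cc(Nc2ncnc3c(NC(=O)Nc4cccc(Cl)c4Cl)cccc23)cc(OC)c1`: 63.2 nM
Compound 2 `COc1cc(Nc2ncnc3c(NC(=O)Nc4ccc(C(F)(F)F)cc4)cccc23)cc(OC)c1`: 3920 nM

In a functional assay on RT-112 cells (Homo sapiens) for antiproliferative activity, read by MTT assay, with a stated time of 72 h (on this read-out higher numbers stand for weaker inhibition of growth and lower numbers for stronger inhibition of growth), compound 2 gives 3920 nM, the higher of the two numbers. Compound 3 `COc1cc(Nc2ncnc3c(NC(=O)c4ccc(CN(C)C)cc4)cccc23)cc(OC)c1` changes the group on the carbonyl carbon: 4-((dimethylamino)methyl)phenyl in place of (4-(trifluoromethyl)phenyl)amino on a carbonyl carbon. Within the data shown here, the only measured step, a 62-fold higher number from compound 1 to compound 2 (1.79 log units; beyond the scatter), is large, so a change in this part of the molecule can matter greatly. That step involves a different group, so it gives only a rough guide, but compound 1 at 63.2 nM shows that the shared core can reach much lower numbers. The estimated move is a 7.8-fold lower number from compound 2 to compound 3 (0.89 log units; beyond the scatter). Compound 3 is expected at 500 nM, within a range of 80 nM to 3000 nM.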

Compound 3, concentration for 50% growth inhibition: 4370 nM
Compound 3: middle estimate off by 8.7-fold (0.94 log units), on the low side; measured number above the stated range.
By their numbers in this assay, from the lowest: compound 1; then compounds 2 and 3 (each within the scatter of the next).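

In this assay, placing 4-((dimethylamino)methyl)phenyl on the carbonyl carbon in place of (4-(trifluoromethyl)phenyl)amino gives a 1.1-fold higher number from compound 2 to compound 3 (0.05 log units; within the scatter) and so leaves the read-out unchanged within the scatter, even though this swap removes the amide-type nitrogen of the departing group. The step of a 69-fold higher number from compound 1 to compound 3 (1.84 log units; beyond the scatter) is large, so among these three compounds only the (2,3-dichlorophenyl)amino group gives a low number. No measurement shown here explains these results. Still open, going by these compounds, is how a morpholine or a piperazine in place of the dimethylamino group would read.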